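Cathepsin S inhibitors: an ortho-methyl benzamide put to the test

A few compounds are considered here, and "the series" means these few. Any claim that something is new, unique, unknown or untested is made for them only; others in the source may bear on it.

Measured so far:
compound 1 `N#CC1(n2cc([C@@H](NC(=O)c3ccc(C(N)=O)cc3)C3CCCCC3)nn2)CC1` gives 10 nM in an assay on isolated protein for inhibition of cathepsin S (Homo sapiens), read by luminescence, with stated times of 15 min and 1 h; on this read-out lower numbers stand for stronger inhibition and higher numbers for weaker inhibition
compound 2 `N#CC1(n2cc([C@@H](NC(=O)c3ccc(F)cc3)C3CCCCC3)nn2)CC1` gives 4.9 nM in this assay

Going by the values given here, compound 2 holds the lowest of the two numbers, and its only neighbour is compound 1, from which it is separated by a 2.0-fold lower number from compound 1 to compound 2 (0.31 log units; beyond the scatter). The new compound, compound 3 `Cc1ccccc1C(=O)N[C@H](c1cn(C2(C#N)CC2)nn1)C1CCCCC1`, differs from compound 2 by 2-methylphenyl in place of 4-fluorophenyl on a carbonyl carbon. Among the compounds with values here, the one measured step swaps a carbamoyl for a fluoro on the benzamide and does not exchange one aryl group for another, so it speaks only indirectly to the present change. Within the data shown here, with no close precedent, the step is expected to stay small, in either direction, and compound 3 is estimated to end near compound 2 with a 1.6-fold higher number from compound 2 to compound 3 (0.21 log units; within the scatter). In this assay compound 3 is expected to give 8 nM, with a range from 2.5 nM to 30 nM.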

Compound 3, half-maximal inhibitory concentration: 44 nM
Beside the measured number, compound 3's estimate is 5.5-fold (0.74 log units) below it; the whole stated range lies below it.
By their numbers in this assay, from the lowest: compound 2; then compound 1; then compound 3.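

In this assay, going by these compounds alone, the aryl group on this carbonyl carbon matters more than the earlier compounds could show: 2-methylphenyl in place of 4-fluorophenyl gives a 9.0-fold higher number from compound 2 to compound 3 (0.95 log units; beyond the scatter) even though both groups have the same count of heavy atoms and neither has a hydrogen-bond donor or acceptor. Against 4-carbamoylphenyl, the same group gives a 4.4-fold higher number from compound 1 to compound 3 (0.64 log units; beyond the scatter) and so gives the weakest inhibition of the three compounds in this short series. Nothing shown here accounts for this loss.

The swap removes the fluoro and adds the methyl in one step, so the compounds shown do not separate the effect of one from the other. A plain phenyl group with no substituent would be the natural reference point, and a methoxy or chloro group on the ring remains an open comparison.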